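Cyano in Place of Methyl on Compound 3

The source may report more compounds than this note shows. Statements on the series, on what has been measured and on what is new or still open speak of the compounds shown alone.

Compound 3 `Cc1cc(-c2c(C)nn(C)c2C)ccc1-c1nnc(N(C)Cc2ccc3nccn3c2)o1` gives 398 nM in an assay on COS-7 cells for inhibition of tyrosine-protein kinase receptor UFO (Homo sapiens), read by ELISA, with a stated time of 1 h (a lower number here means a stronger inhibitor, a higher number a weaker inhibitor), the lowest of the three numbers recorded. Compound 1 `Cc1nn(C)c(C)c1-c1ccc(-c2nnc(N(C)Cc3ccc4nccn4c3)o2)cc1` gives 3160 nM and compound 2 `Cc1nn(C)c(C)c1-c1ccc(-c2nnc(N(C)Cc3ccc4nccn4c3)o2)c(F)c1` gives 3160 nM. The step of no change at the digits printed from compound 1 to compound 2 (within the scatter) lies within the scatter, whereas the steps of a 7.9-fold lower number from compound 1 to compound 3 (0.90 log units; beyond the scatter) and a 7.9-fold lower number from compound 2 to compound 3 (0.90 log units; beyond the scatter) are modest but beyond it, each coming from a methyl set on an aromatic carbon.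

Compound 4 `Cc1cc(-c2c(C#N)nn(C)c2C)ccc1-c1nnc(N(C)Cc2ccc3nccn3c2)o1` differs from compound 3 by cyano in place of methyl on an aromatic carbon of the five-membered aromatic ring with 2 nitrogen. None of the three measured steps involves a change of this kind, so they offer no direct guide to its effect. Among the measured compounds shown here, with no precedent to lean on, compound 4 is expected to lie close, with an estimated step of a 1.0-fold higher number from compound 3 to compound 4 (0.00 log units; within the scatter) of no clear direction. Compound 4 is therefore estimated at 400 nM in this assay, with a range from 100 nM to 1600 nM.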

Compound 4, half-maximal inhibitory concentration: 6310 nM
Beside the measured number, compound 4's estimate is 16-fold (1.20 log units) below it; measured number above the stated range.
By their numbers in this assay, from the lowest: compound 3; then compounds 1, 2 and 4 (each within the scatter of the next).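

Until compound 4, every step had left the 1,3,5-trimethyl-1H-pyrazol-4-yl group untouched, so nothing showed whether this group could be altered without consequence. In this assay, cyano in place of methyl on the aromatic carbon next to the ring nitrogen gives a 16-fold higher number from compound 3 to compound 4 (1.20 log units; beyond the scatter), a large step and the only one here that weakens inhibition beyond the scatter. This position is therefore not indifferent to its substituent, at least on the core of compound 3, although nothing shown accounts for the size of the step.

A single replacement cannot separate the effect of losing the methyl from that of adding the cyano. As far as these compounds go, how an ethyl group, a chlorine atom or a primary amide at this carbon would compare remains open, as does whether the same step would appear on the cores of compound 1 and compound 2.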